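Methoxy in Place of Hydrogen on a Cinnamate Ester

A few compounds are considered here, and "the series" means these few. Any claim that something is new, unique, unknown or untested is made for them only; others in the source may bear on it.

Two compounds built on a shared core, each carrying an aromatic ester, have been tested in a functional assay on Raji cells (Homo sapiens) for antiproliferative activity, read by MTT assay, with a stated time of 6 days; a higher number here means a weaker inhibitor, a lower number a stronger inhibitor. Compound 1 `CC(=O)O[C@@H]1C=CC(=O)O[C@@H]1[C@@H](COC(=O)c1ccc(Cl)cc1)OC(C)=O` gives 1850 nM in this assay. Compound 2 `O=C1C=C[C@@H](OCc2ccccc2)[C@@H]([C@@H](COC(=O)/C=C/c2ccccc2)OCc2ccccc2)O1` gives 1330 nM, and these two values lie within the scatter of each other, so neither stands apart. Compound 3 `COc1ccc(/C=C/C(=O)OC[C@@H](OCc2ccccc2)[C@H]2OC(=O)C=C[C@H]2OCc2ccccc2)cc1` is compound 2 with methoxy in place of hydrogen on an aromatic carbon. Going by the values given here, no measured pair shows this change, so the expected step is a 1.1-fold lower number from compound 2 to compound 3 (0.04 log units; within the scatter), not beyond the scatter in either direction. Compound 3 is therefore estimated at 1200 nM, within 450 nM to 3200 nM.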

Compound 3, half-maximal inhibitory concentration: 690 nM
Beside the measured number, compound 3's estimate is 1.7-fold (0.24 log units) above it; the range from low to high includes it.
By their numbers in this assay, from the lowest: compounds 3, 2 and 1 (each within the scatter of the next, the first and the last beyond it).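

Going from phenyl to 4-methoxyphenyl in this assay gives a 1.9-fold lower number from compound 2 to compound 3 (0.29 log units; within the scatter), the first direct reading of any change at this aromatic carbon. The step shows that this ring accepts methoxy, para to a large group, without a shift beyond the scatter. No measurement offers an explanation for the size of this step.

As far as these compounds go, it remains open whether a different group at this carbon, such as an amine or ethoxy, would move the number beyond the scatter. From the compounds shown here alone, the effect of methoxy on the other carbons of this ring also remains open.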